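A few compounds are considered here, and "the series" means these few. Any claim that something is new, unique, unknown or untested is made for them only; others in the source may bear on it.

Compound 1 `CCCCCCCCO[C@@H]1O[C@@H](C)[C@H](OC(=O)CCCCC)[C@@H](O[C@@H]2O[C@@H](C)[C@H](OC(C)=O)[C@@H](O[C@@H]3O[C@@H](C)[C@H](OC(C)=O)[C@@H](OC(C)=O)[C@H]3O)[C@H]2OC(C)=O)[C@H]1O` is the larger of the two measured compounds. In a functional assay on KB cells (Homo sapiens) for cytotoxicity, in the presence of a further agent that is not named here (a lower number here means that less compound is needed, a higher number that more compound is needed for the effect), compound 1 gives > 20 ug/mL, which is a limit of the assay rather than a measured number, as one of the two values here sits at the limit of > 20 ug/mL in this assay, at which 1 of the 2 values shown sits. Compound 2 `CCCCCCCCO[C@@H]1O[C@@H](C)[C@H](OC(=O)CCCCC)[C@@H](O[C@@H]2O[C@@H](C)[C@H](OC(C)=O)[C@@H](OC(C)=O)[C@H]2OC(C)=O)[C@H]1O` is a smaller relative of compound 1, and in this assay compound 2 gives 5.6 ug/mL, an actual number. The unmeasured compound 3 `CCCCCCCCO[C@@H]1O[C@@H](C)[C@H](OC(=O)CCCCC)[C@@H](O[C@@H]2O[C@@H](C)[C@H](OC(C)=O)[C@@H](O[C@@H]3O[C@@H](C)[C@H](OC(C)=O)[C@@H](O)[C@H]3O)[C@H]2OC(C)=O)[C@H]1O` differs from compound 1 in a single place: hydrogen in place of acetyl on an oxygen on a saturated carbon. Cut one bond further out, the same change reads as acetoxy to hydroxy. For the measured compounds named here, no measured pair shows this change, so its size cannot be read from the compounds at hand. The step from compound 1 to compound 3 is expected to be small, a number no higher from compound 1 to compound 3 (the limit leaves the size open), staying within the scatter or leaning slightly toward less compound being needed. Compound 3 is therefore estimated at 20 ug/mL, with a range from 8 ug/mL to 40 ug/mL.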

Compound 3, concentration for half-maximal effect: > 20 ug/mL
Compound 3: a limit, no number; the forecaster's own chance of this, stated with the estimate: 60%; the middle value lies on the limit itself.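

In this assay compound 3 gives > 20 ug/mL, which is a limit of the assay and not a number. For the compounds shown here, compound 1 also stands at a limit, so no step between compound 1 and compound 3 can be read. The compounds shown leave open whether swapping acetoxy for hydroxy at this place changes the amount of compound needed at all.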